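Methyl to chloro on the outer phenyl ring

The compounds below may be only part of what the source reports. "The series", "measured", "known", "first", "only" and "open" are said of these compounds alone.

Of the compounds shown here, two have numbers so far. Going by the values given here, compound 1 `O=c1[nH]cc(S(=O)(=O)Nc2ccccc2-c2cn(-c3ccccc3)nn2)c(=O)[nH]1` and compound 2 `Cc1cccc(-n2cc(-c3cccc(NS(=O)(=O)c4c[nH]c(=O)[nH]c4=O)c3)nn2)c1` share the same core but differ in more than one place, so no single step joins them. In an ADME assay on L02 cells (Homo sapiens) for cytotoxicity, read by MTT assay, with a stated time of 24 h (on this read-out higher numbers stand for lower toxicity in this test and lower numbers for higher toxicity in this test), compound 1 gives 10600 nM. In this assay compound 2 gives 28300 nM, the higher of the two numbers obtained so far, and the gap to compound 1 lies beyond the usual scatter.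

Compound 3 `O=c1[nH]cc(S(=O)(=O)Nc2cccc(-c3cn(-c4cccc(Cl)c4)nn3)c2)c(=O)[nH]1` has not yet been measured in this assay. It differs from compound 2 by chloro in place of methyl on an aromatic carbon. Among the compounds with values here, no measured pair shows what this swap does in this read-out, so the expectation rests on the small size of the change alone. A step of about a 1.2-fold lower number from compound 2 to compound 3 (0.07 log units; within the scatter) is expected, that is, no shift beyond the usual scatter in either direction. For compound 3 the estimate in this assay is 24000 nM, with a range from 9000 nM to 65000 nM.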

Compound 3, half-maximal cytotoxic concentration: 8330 nM
The estimate for compound 3 lay 2.9-fold (0.46 log units) above the measured number; measured number below the stated range.
By their numbers in this assay, from the lowest: compounds 3 and 1 (each within the scatter of the next); then compound 2.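

In this assay, the exchange of 3-methylphenyl for 3-chlorophenyl gives a 3.4-fold lower number from compound 2 to compound 3 (0.53 log units; beyond the scatter). Going by these compounds alone, this is the first step that can be read at a single place, and it shows that this position on the outer phenyl ring is not silent in this read-out: replacing one heavy atom with another, with no change in ring count or in hydrogen-bond donor and acceptor counts, moves the number beyond the usual scatter, and the direction is towards higher toxicity in this test. Nothing at hand accounts for the step, so it stands as an observation on this one pair.

On these data alone, what a fluoro group, a methoxy group or an amine would do at this same place remains open, as does whether the step follows from the arrival of chloro or from the departure of methyl. Within the data shown here, with only one pair joined by this change, it is also open whether the same exchange would give a step of similar size and direction on the outer phenyl ring of compound 1.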